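The source may hold more compounds than are shown below. What is called first, only, known or untested is meant among the compounds shown, and "the series" means these compounds.

In a functional assay on Ehrlich cells (Mus musculus) for cytotoxicity, read by MTT assay, with a stated time of 48 h (on this read-out higher numbers stand for weaker inhibition and lower numbers for stronger inhibition), compound 2 `Cc1cc(C(=O)c2ccccc2F)ccc1OCC(=O)Nc1nc(-c2ccccc2)cs1` gives 16700 nM, and compound 1 `Cc1cc(C(=O)c2ccccc2)ccc1OCC(=O)Nc1nc(-c2ccccc2)cs1` gives 24000 nM; the two numbers stand within the scatter of each other, as the step of a 1.4-fold lower number from compound 1 to compound 2 (0.16 log units; within the scatter) shows. Compound 3 `Cc1cc(C(=O)c2ccccc2C)ccc1OCC(=O)Nc1nc(-c2ccccc2)cs1` differs from compound 2 by methyl in place of fluoro on an aromatic carbon, a change made at the carbon where that earlier step occurred. Since that step stayed within the scatter, and nothing measured points elsewhere, no step beyond the scatter is expected here. Compound 3 is therefore estimated at 15000 nM, with a range from 7000 nM to 35000 nM. The expected step of a 1.1-fold lower number from compound 2 to compound 3 (0.05 log units; within the scatter) thus means no change beyond the scatter.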

Compound 3, half-maximal inhibitory concentration: 25800 nM
Compound 3: middle estimate off by 1.7-fold (0.24 log units), on the low side, within the range that was stated.
By their numbers in this assay, from the lowest: compounds 2, 1 and 3 (each within the scatter of the next).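

In this assay, methyl at this carbon, ortho to a large group, stays within the scatter of fluoro (a 1.5-fold higher number from compound 2 to compound 3 (0.19 log units; within the scatter)) and of hydrogen (a 1.1-fold higher number from compound 1 to compound 3 (0.03 log units; within the scatter)). The earlier pair covered only hydrogen and fluoro, so a carbon-based group now joins them, and these three compounds cannot be told apart at this position. No measurement is available to explain this outcome. Open, on these data alone, is whether a larger or charged group here, such as an amine or a carboxylic acid, would move the number beyond the scatter.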